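From 2-oxopropyl to 2-acetoxyethyl on a shared core

The compounds below may be only part of what the source reports. "The series", "measured", "known", "first", "only" and "open" are said of these compounds alone.

Values measured so far in a functional assay (trachea) with Cavia porcellus as the target; a lower number here means a stronger inhibitor, a higher number a weaker inhibitor
- Compound 1 `CCCCn1nc(-c2cccnc2)c2ccccc2c1=O` gives 2290 nM
- Compound 2 `O=c1c2ccccc2c(-c2cccnc2)nn1C1CCCC1` gives 2750 nM
- Compound 3 `CC(=O)Cn1nc(-c2cccnc2)c2ccccc2c1=O` gives 40700 nM

Compound 3 has the highest number of the three and is the weakest inhibitor here. Compound 4 `CC(=O)OCCn1nc(-c2cccnc2)c2ccccc2c1=O` has not been measured yet. It differs from compound 3 on a saturated chain carbon bound to an aromatic nitrogen, where acetoxymethyl stands in place of acetyl (acetoxymethyl in place of acetyl on a saturated chain carbon bound to an aromatic nitrogen).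

For the measured compounds named here, three measured steps bear on this side chain. Cyclopentyl in place of butyl gives a 1.2-fold higher number from compound 1 to compound 2 (0.08 log units; within the scatter) and so separates nothing. The other two are large: an 18-fold higher number from compound 1 to compound 3 (1.25 log units; beyond the scatter) and a 15-fold higher number from compound 2 to compound 3 (1.17 log units; beyond the scatter) for the chain that compound 3 carries. Going by the values given here, no measured compound tests an acetoxy group directly. Compound 4 keeps a carbonyl in its chain, as compound 3 does, but on a bigger group, so only part of the gap shown by an 18-fold higher number from compound 1 to compound 3 (1.25 log units; beyond the scatter) is expected to close. The estimated change in this assay is a 2.3-fold lower number from compound 3 to compound 4 (0.35 log units; beyond the scatter) and is expected to be modest. For compound 4 the estimated value is 18000 nM with an expected range from 6000 nM to 50000 nM when it is measured.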

Compound 4, half-maximal inhibitory concentration: 9770 nM
Compound 4: middle estimate off by 1.8-fold (0.27 log units), on the high side; measured number inside the range.
By their numbers in this assay, from the lowest: compounds 1 and 2 (each within the scatter of the next); then compound 4; then compound 3.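

In this assay, replacing the 2-oxopropyl chain with 2-acetoxyethyl recovers part of the lost inhibition (a 4.2-fold lower number from compound 3 to compound 4 (0.62 log units; beyond the scatter)), so a carbonyl-bearing chain at this position need not be as costly as compound 3 alone suggested. The recovery is incomplete, however: compound 4 remains a weaker inhibitor than both carbonyl-free compounds (a 3.6-fold higher number from compound 2 to compound 4 (0.55 log units; beyond the scatter); a 4.3-fold higher number from compound 1 to compound 4 (0.63 log units; beyond the scatter)). No measurement here explains why the 2-acetoxyethyl chain fares better than the 2-oxopropyl chain.

From the compounds shown here alone, it remains open whether the improvement depends on the ester itself or simply on the longer chain. A 3-oxobutyl chain or a 2-hydroxyethyl group on the shared core would help separate these two possibilities.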